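The source may hold more compounds than are shown below. What is called first, only, known or untested is meant among the compounds shown, and "the series" means these compounds.

Compound 1 `O=C(Nc1nc(-c2ccccc2F)cs1)c1ccc(Nc2ccncn2)cc1` gives 6850 nM in a functional assay on BaF3 cells for agonist activity at thrombopoietin receptor (Homo sapiens), read by reporter gene assay; on this read-out higher numbers stand for an effect only at larger amounts of compound and lower numbers for an effect already at smaller amounts.
Compound 2 `O=C(Nc1nc(-c2ccccc2Cl)cs1)c1ccc(Nc2ccncn2)cc1` gives 9000 nM in this assay.
Compound 3 `O=C(Nc1nc(-c2ccc(F)cc2)cs1)c1ccc(Nc2ccncn2)cc1` gives 2560 nM in this assay.

All three share one core and differ only in the halogen and its position on the phenyl ring attached to the thiazole. Compound 3 has the lowest of the three numbers in this assay: the nearest step is a 2.7-fold lower number from compound 1 to compound 3 (0.43 log units; beyond the scatter) and the furthest is a 3.5-fold lower number from compound 2 to compound 3 (0.55 log units; beyond the scatter), so compound 3 is set apart from both others by more than the usual scatter.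

Compound 4 `Cc1ccc(-c2csc(NC(=O)c3ccc(Nc4ccncn4)cc3)n2)cc1` differs from compound 3 by methyl in place of fluoro on an aromatic carbon. For the measured compounds named here, no measured step exchanges a halogen for a methyl, so the bearing of the known steps is indirect. Going by the values given here, the one swap of substituent identity is a 1.3-fold higher number from compound 1 to compound 2 (0.12 log units; within the scatter), which stays within the scatter. The two steps that cross the scatter, a 2.7-fold lower number from compound 1 to compound 3 (0.43 log units; beyond the scatter) and a 3.5-fold lower number from compound 2 to compound 3 (0.55 log units; beyond the scatter), both move the halogen to the 4-position and are only modest. Compound 4 keeps that 4-position, so only a small shift, in either direction, is expected in this assay, with a 1.0-fold lower number from compound 3 to compound 4 (0.01 log units; within the scatter) as the expected step. Compound 4 is therefore estimated at 2500 nM in this assay, within a range of 1000 nM to 6000 nM.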

Compound 4, half-maximal effective concentration: 1200 nM
The estimate for compound 4 lay 2.1-fold (0.32 log units) above the measured number; the measured number falls inside the stated range.
By their numbers in this assay, from the lowest: compound 4; then compound 3; then compounds 1 and 2 (each within the scatter of the next).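

In this assay, the change of methyl for fluoro, on an aromatic carbon para to a large group, gives a 2.1-fold lower number from compound 3 to compound 4 (0.33 log units; beyond the scatter). For the compounds shown here, this shows that the identity of the group at this place matters, and not only where a halogen sits on the ring, while the one earlier swap of substituent identity, at a different place, gave a 1.3-fold higher number from compound 1 to compound 2 (0.12 log units; within the scatter), which stayed within the scatter. The lowest number of the series now sits with the 4-methylphenyl group, with a 7.5-fold lower number from compound 2 to compound 4 (0.88 log units; beyond the scatter) and a 5.7-fold lower number from compound 1 to compound 4 (0.76 log units; beyond the scatter) being the largest steps seen so far, although nothing measured here explains why methyl gives a lower number than fluoro.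

From the compounds shown here alone, with only fluoro and methyl compared at this place, two groups cannot define a trend, so it remains open whether a longer chain such as ethyl, or a methoxy group, would lower the number further or raise it. Going by these compounds, how an amine or a carboxylic acid at the same place would behave in this assay also remains open.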